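This account rests on a few compounds, and the source may have more. Where it says the series, first, only, none or still open, it means among the compounds named here.

Measured so far:
- compound 1 `COc1ccc(OC)c(/C=N/NC(=O)Nc2ccc(Oc3ccnc(-c4nncn4CCN(C)C)c3)c(F)c2)c1`: 2930 nM
- compound 2 `CN(C)CCn1cnnc1-c1cc(Oc2ccc(NC(=O)N/N=C/c3ccc(Cl)cc3)cc2F)ccn1`: 320 nM

Among the compounds with values here, in a functional assay on NCI-H460 cells (Homo sapiens) for cytotoxicity, read by MTT assay, with a stated time of 72 h (a lower number here means a stronger inhibitor, a higher number a weaker inhibitor), compound 2 gives the lowest of the two numbers; the only neighbour is compound 1, higher by a 9.2-fold lower number from compound 1 to compound 2 (0.96 log units; beyond the scatter). Compound 3 `COc1cc(/C=N/NC(=O)Nc2ccc(Oc3ccnc(-c4nncn4CCN(C)C)c3)c(F)c2)ccc1O` differs from compound 2 by 4-hydroxy-3-methoxyphenyl in place of 4-chlorophenyl on a carbon with a double bond to nitrogen. Within the data shown here, the one step that bears on this, a 9.2-fold lower number from compound 1 to compound 2 (0.96 log units; beyond the scatter), ran from an oxygen-substituted phenyl to 4-chlorophenyl and was modest but beyond the scatter; the present change goes back to an oxygen-substituted phenyl. A rise in this assay of roughly that size is therefore expected, a 6.3-fold higher number from compound 2 to compound 3 (0.80 log units; beyond the scatter). Compound 3 is estimated at 2000 nM, between 600 nM and 6000 nM.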

Compound 3, half-maximal inhibitory concentration: 57 nM
Compound 3: the middle estimate sits 35-fold (1.55 log units) above what was measured; measured number outside the range, below it.
By their numbers in this assay, from the lowest: compound 3; then compound 2; then compound 1.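

In this assay, an oxygen-substituted phenyl on the carbon with a double bond to nitrogen can give the lowest number of the three: 4-hydroxy-3-methoxyphenyl beats 4-chlorophenyl (a 5.6-fold lower number from compound 2 to compound 3 (0.75 log units; beyond the scatter)) and 2,5-dimethoxyphenyl (a 51-fold lower number from compound 1 to compound 3 (1.71 log units; beyond the scatter)). The two oxygen-substituted phenyls therefore stand at opposite ends of the three, with 4-chlorophenyl in the middle. (No measurement at hand accounts for this order)

The compounds shown do not separate the contribution of the hydroxy group from that of the methoxy group. A 4-hydroxyphenyl or a 4-aminophenyl at this place would bear on that question.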